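Sulfonyl for carbonyl on the linker nitrogen

A few compounds are considered here, and "the series" means these few. Any claim that something is new, unique, unknown or untested is made for them only; others in the source may bear on it.

Within the data shown here, compound 1 `CN(C(=O)c1ccc(Cl)cc1)c1ccc2[nH]c(-c3n[nH]c4ccccc34)cc2n1` gives 3000 nM in a functional assay on HCT-116 cells (Homo sapiens) for antiproliferative activity, read by MTT assay, with a stated time of 72 h (on this read-out lower numbers stand for stronger inhibition and higher numbers for weaker inhibition), the lowest of the three numbers so far. Compound 2 `CN(C(=O)c1ccc([N+](=O)[O-])cc1)c1ccc2[nH]c(-c3n[nH]c4ccccc34)cc2n1` gives 19900 nM in this assay, and compound 3 `CN(C(=O)c1ccccc1)c1ccc2[nH]c(-c3n[nH]c4cc(C#N)ccc34)cc2n1` gives 24000 nM in this assay. Among the measured compounds shown here, the one single-point step, a 6.6-fold higher number from compound 1 to compound 2 (0.82 log units; beyond the scatter), alters a group on the pendant aromatic ring rather than the linker. Compound 4 `CN(c1ccc2[nH]c(-c3n[nH]c4ccccc34)cc2n1)S(=O)(=O)c1ccc(Br)cc1` differs from compound 1 by (4-bromophenyl)sulfonyl in place of (4-chlorophenyl)carbonyl on a nitrogen on an aromatic ring. For the measured compounds named here, no measured step exchanges the carbonyl for a sulfonyl, and bromo for chloro is also untested, so the direction is open; the step from compound 1 to compound 2 shows only that altering that ring can cost potency. For compound 4 a modest weakening is expected, a 2.0-fold higher number from compound 1 to compound 4 (0.30 log units; within the scatter), with a wide range. Compound 4 is therefore estimated at 6000 nM in this assay, between 1500 nM and 25000 nM.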

Compound 4, half-maximal inhibitory concentration: 9850 nM
Beside the measured number, compound 4's estimate is 1.6-fold (0.22 log units) below it; measured number inside the range.
By their numbers in this assay, from the lowest: compound 1; then compound 4; then compounds 2 and 3 (each within the scatter of the next).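

The linker nitrogen now has its first reading: in this assay, replacing the acyl group with a sulfonyl one gives a 3.3-fold higher number from compound 1 to compound 4 (0.52 log units; beyond the scatter), a real weakening of modest size. The step changes the linking group and the halogen together, so it cannot assign the loss to either change alone. Nothing available explains this loss.

Still open, going by these compounds, is how (4-chlorophenyl)sulfonyl or (4-bromophenyl)carbonyl would read, as either would split this step. Also open, on these data alone, is how an amine or a carboxylic acid on the pendant ring would compare with the halogens.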